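This account rests on a few compounds, and the source may have more. Where it says the series, first, only, none or still open, it means among the compounds named here.

Working notes on the series. Compound 1 `COc1ccc(OC)c(Sc2ccc3nnc(-c4cccnc4)n3n2)c1` carries a pyridin-3-yl group on the shared core; in an assay on HEK293 cells for inhibition of Leucine-rich repeat serine/threonine-protein kinase 2 (Homo sapiens), read by ELISA, with a stated time of 90 min (on this read-out higher numbers stand for weaker inhibition and lower numbers for stronger inhibition), compound 1 gives 736 nM. Going by the values given here, compound 2 `COc1ccc(OC)c(Sc2ccc3nnc(-c4cnccn4)n3n2)c1` belongs to the same series, yet in this assay compound 2 gives "not determined" (no result reported), so compound 1 supplies the only number now in hand and nothing can be compared against it. Compound 3 `COc1ccc(OC)c(Sc2ccc3nnc(-c4ccsn4)n3n2)c1` differs from compound 1 in one place: 1,2-thiazol-3-yl in place of pyridin-3-yl on an aromatic carbon. Among the compounds with values here, no measured pair that shares this change exists, so the size of the step rests on judgment alone. A small shift toward weaker inhibition is expected, not clearly beyond the scatter, and the estimated step in this assay is a 1.5-fold higher number from compound 1 to compound 3 (0.17 log units; within the scatter). In this assay compound 3 is expected to give about 1100 nM, with a plausible range from 350 nM to 3500 nM.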

Compound 3, half-maximal inhibitory concentration: 722 nM
Compound 3: middle estimate off by 1.5-fold (0.18 log units), on the high side, within the range that was stated.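

In this assay the exchange of pyridin-3-yl for 1,2-thiazol-3-yl on this aromatic carbon gives a 1.0-fold lower number from compound 1 to compound 3 (0.01 log units; within the scatter) and so leaves the read-out unresolved from compound 1. This first pair with two numbers shows that, at this position, a five-membered aromatic ring with 2 hetero atoms, one of them sulfur, reads the same as a six-membered aromatic ring with 1 hetero atom. No measurement at hand accounts for the two rings reading alike.

Both groups are aromatic rings, so the compounds shown leave open how a morpholine, a primary amine or a carboxylic acid would read on this carbon. Also open, from the compounds shown here alone, is how a chlorine atom in place of a methoxy group on the shared core would read in this assay against compound 1.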